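Halogen swap on the phenyl ring of the series

The source may hold more compounds than are shown below. What is called first, only, known or untested is meant among the compounds shown, and "the series" means these compounds.

Compound 1 `O=[N+]([O-])c1ccc(N/C(=N\O)c2cccc(F)c2)c2nonc12` and compound 2 `O=[N+]([O-])c1ccc(N/C(=N\O)c2ccc(F)cc2)c2nonc12` share one core and differ only in where the fluorine sits. In an assay on isolated protein for inhibition of Tryptophan 2,3-dioxygenase (Homo sapiens), read by spectrophotometry, with a stated time of 1 h (a lower number here means a stronger inhibitor, a higher number a weaker inhibitor), compound 1 gives 45000 nM; compound 2 gives 21000 nM, the lowest of the two numbers, and the step of a 2.1-fold lower number from compound 1 to compound 2 (0.33 log units; beyond the scatter) is modest. Compound 3 `O=[N+]([O-])c1ccc(N/C(=N\O)c2ccc(Cl)cc2)c2nonc12` carries chloro in place of fluoro on an aromatic carbon. Among the compounds with values here, the sole measured step concerns position, not the halogen itself, so no direct precedent exists. The expected step is a 1.4-fold lower number from compound 2 to compound 3 (0.15 log units; within the scatter), not beyond the scatter. Compound 3 is estimated at 15000 nM, between 6000 nM and 40000 nM.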

Compound 3, half-maximal inhibitory concentration: 40000 nM
Estimate against measurement, compound 3: 2.7-fold (0.43 log units) below, within the range that was stated.
By their numbers in this assay, from the lowest: compounds 2, 3 and 1 (each within the scatter of the next, the first and the last beyond it).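

In this assay, chloro in place of fluoro on this aromatic carbon, para to a large group, gives a 1.9-fold higher number from compound 2 to compound 3 (0.28 log units; within the scatter), so the two halogens are not separated at this position. The change from 3-fluorophenyl to 4-chlorophenyl gives a 1.1-fold lower number from compound 1 to compound 3 (0.05 log units; within the scatter), which likewise leaves those two compounds unseparated. No supporting evidence is available to account for either step.

On these data alone, it remains open whether an amine or a carboxylic acid on this aromatic carbon would give a step beyond the scatter. As far as these compounds go, whether bromo would separate from fluoro or chloro also remains open.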